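The source may hold more compounds than are shown below. What is called first, only, known or untested is meant among the compounds shown, and "the series" means these compounds.

Series notes. Compound 1 `COc1ccc(F)cc1CNCCCNc1ccnc2cc(Cc3ccc(C#N)cc3)ccc12` is the reference point; in an ADME assay for permeability, using PAMPA, with a stated time of 30 min, at pH 7.4 (on this read-out higher numbers stand for higher permeability and lower numbers for lower permeability), compound 1 gives 23 10^-6 cm/s. Compound 2 `Cc1cc(C)cc(Cc2ccc3c(NCCCNCc4ccco4)ccnc3c2)c1` gives 23 10^-6 cm/s in this assay, and compound 3 `COc1cccc(CNCCCNc2ccnc3cc(Cc4ccc(C#N)cc4)ccc23)c1O` gives 23 10^-6 cm/s. Compound 1 thus stands level with compounds 2 and 3 at the digits shown, within the scatter of the method: nearest is compound 2 and furthest compound 3, with no change in either case. Going by the values given here, the one single-point step measured so far, no change at the digits printed from compound 1 to compound 3 (within the scatter), exchanges the group on a saturated chain carbon bound to an amine nitrogen and leaves the read-out flat.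

The next compound, compound 4 `COc1ccc(F)cc1CNCCCNc1ccnc2cc(Oc3ccc(Cl)cc3)ccc12`, differs from compound 1 as follows: 4-chlorophenoxy in place of 4-cyanobenzyl on an aromatic carbon. Of the measured steps only no change at the digits printed from compound 1 to compound 3 (within the scatter) bears on this, and only indirectly, since it concerns the saturated chain carbon bound to an amine nitrogen rather than the aromatic carbon changed here. With all three measured compounds sitting at the same value and nothing in the data pointing to a shift beyond the scatter, the expected step is no change at the digits printed from compound 1 to compound 4 (within the scatter), that is, none beyond the scatter. Compound 4 is therefore estimated at 23 10^-6 cm/s in this assay, with a range from 11 10^-6 cm/s to 45 10^-6 cm/s.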

Compound 4, apparent permeability: 317 10^-6 cm/s
Compound 4: middle estimate off by 14-fold (1.14 log units), on the low side, and the stated range ends below it.
By their numbers in this assay, from the lowest: compounds 1, 2 and 3 (each within the scatter of the next); then compound 4.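

In this assay, going by these compounds alone, this aromatic carbon of the shared core responds strongly to its substituent: 4-chlorophenoxy in place of 4-cyanobenzyl gives a 14-fold higher number from compound 1 to compound 4 (1.14 log units; beyond the scatter), whereas the only earlier single-point step, at the saturated chain carbon bound to an amine nitrogen, gave no change at the digits printed from compound 1 to compound 3 (within the scatter). The large step comes with little change in the counted features, as both groups carry one six-membered aromatic ring of carbon only, the same hydrogen-bond donor and acceptor counts and no net charge, while the triple bond leaves and oxygen and chlorine enter. No measurement in hand accounts for the size of this step.

From the compounds shown here alone, the step changes the link to the core and the group on the outer ring together, so the share of each remains open; 4-cyanophenoxy and 4-chlorobenzyl on the same aromatic carbon would separate the two. Also open, going by these compounds, is whether the saturated chain carbon stays as flat with 4-chlorophenoxy on the core, which a 2-hydroxy-3-methoxyphenyl counterpart of compound 4 would show.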